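Dropping the fluorine from compound 3: what to expect

The source may report more compounds than this note shows. Statements on the series, on what has been measured and on what is new or still open speak of the compounds shown alone.

Compound 1 `O=C(Nc1ccc(Oc2ccnc3[nH]ccc23)cc1)c1nccc(-c2cccc(Cl)c2)n1` and compound 2 `COc1ccc(-c2ccnc(C(=O)Nc3ccc(Oc4ccnc5[nH]ccc45)cc3)n2)cc1` share a core and differ only in the pendant aryl group. In a functional assay on PC-3 cells (Homo sapiens) for cytotoxicity, read by MTT assay, with a stated time of 72 h (on this read-out higher numbers stand for weaker inhibition and lower numbers for stronger inhibition), compound 1 gives 7800 nM, and compound 2 gives 17300 nM; the step of a 2.2-fold higher number from compound 1 to compound 2 (0.35 log units; beyond the scatter) is modest. Compound 3 `O=C(Nc1ccc(Oc2ccnc3[nH]ccc23)cc1)c1cc(-c2ccc(F)cc2)ncn1` carries the same anilide and the same ether linkage on a differently joined core, and in this assay compound 3 was reported as "not active" (no number reported), with no single number attached to it, so its standing on this read-out cannot be placed against compound 1 or compound 2 in figures. Compound 4 `O=C(Nc1ccc(Oc2ccnc3[nH]ccc23)cc1)c1cc(-c2ccccc2)ncn1` differs from compound 3 by hydrogen in place of fluoro on an aromatic carbon, on an aromatic carbon of a six-membered aromatic ring of carbon only. Among the measured compounds shown here, no measured step bears directly on this change; the only step in hand, a 2.2-fold higher number from compound 1 to compound 2 (0.35 log units; beyond the scatter), concerns a different aryl exchange on a different core and was modest. Since compound 3 was not active, compound 4 is expected to be weak as well, with a fair chance that only a limit is reported; the estimate for compound 4 in this assay is 40000 nM, within 10000 nM to 150000 nM.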

Compound 4, half-maximal inhibitory concentration: 240 nM
Beside the measured number, compound 4's estimate is 170-fold (2.22 log units) above it; measured number below the stated range.
By their numbers in this assay, from the lowest: compound 4; then compound 1; then compound 2.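

In this assay, among the compounds shown here, compound 3 carries no number, so no step from compound 3 to compound 4 can be read. The compounds shown leave open what the 4-fluorophenyl to phenyl change does where both partners have a number. Nothing at hand offers an explanation for the result of compound 4.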